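This account rests on a few compounds, and the source may have more. Where it says the series, first, only, none or still open, it means among the compounds named here.

The measured compounds:

compound 1, `CC(C)(C)c1ccc(C(=O)NN2C(=O)NC3(CC3(C)C)C2=O)cc1`: 100 mg/kg
compound 2, `CC1(C)CC12NC(=O)N(NC(=O)c1ccc(F)cc1)C2=O`: 300 mg/kg
compound 3, `CC1(C)CC12NC(=O)N(NC(=O)c1ccc([N+](=O)[O-])cc1)C2=O`: 300 mg/kg

All three were tested in a functional assay on the whole organism (Hindlimb) for inhibition, with Mus musculus as the target, with a stated time of 4 h; a lower number here means that less compound is needed, a higher number that more compound is needed for the effect. Compound 2 stands level with compound 3 at the digits given, the two together holding the highest numbers, while compound 1 lies apart by a 3.0-fold higher number from compound 1 to compound 2 (0.48 log units; beyond the scatter). Compound 4, `CC1(C)CC12NC(=O)N(NC(=O)c1cccnc1)C2=O`, has not yet been measured; it differs from compound 2 by pyridin-3-yl in place of 4-fluorophenyl on a carbonyl carbon. Within the data shown here, the steps that bear on this change are a 3.0-fold higher number from compound 1 to compound 2 (0.48 log units; beyond the scatter), a 3.0-fold higher number from compound 1 to compound 3 (0.48 log units; beyond the scatter) and no change at the digits printed from compound 2 to compound 3 (within the scatter), each an exchange on the aromatic ring; none replaces the ring itself, so the guidance is limited, and only a modest step or none beyond the scatter is expected. Compound 4 is therefore estimated at 300 mg/kg, within 100 mg/kg to 1000 mg/kg, meaning an expected step of no change at the digits printed from compound 2 to compound 4 (within the scatter).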

Compound 4, minimum effective dose: 300 mg/kg
Beside the measured number, compound 4's estimate shows no gap at the digits printed; the range from low to high includes it.
By their numbers in this assay, from the lowest: compound 1; then compounds 2, 3 and 4 (each within the scatter of the next).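

Unlike the earlier exchanges on the aromatic ring, this one replaces the ring itself on the carbonyl carbon, and in this assay it gives no change at the digits printed from compound 2 to compound 4 (within the scatter) for the swap. At this place, then, a ring with a hetero atom and a hydrogen-bond acceptor stands level with the carbon-only ring. Nothing available accounts for this result.

As far as these compounds go, it remains open whether pyridin-4-yl would read the same as pyridin-3-yl. Also open, from the compounds shown here alone, is whether a saturated group such as cyclohexyl could take the place of the aromatic ring.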